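Notes on the N-aryl pyrazolone amide series: pyrrole N-methylation

The source may report more compounds than this note shows. Statements on the series, on what has been measured and on what is new or still open speak of the compounds shown alone.

The series shares a pyrrolopyrimidine ether amide core and varies the aryl group on the pyrazolone nitrogen. Compound 1 `Cc1cc(=O)n(-c2ccc(F)cc2)nc1C(=O)Nc1ccc(Oc2ncnc3[nH]ccc23)c(F)c1` gives 24500 nM in a functional assay on MCF7 cells (Homo sapiens) for cytotoxicity, read by MTT assay, with a stated time of 72 h; a higher number here means a weaker inhibitor, a lower number a stronger inhibitor. Compound 2 `Cc1cc(=O)n(-c2ccccc2OC(F)(F)F)nc1C(=O)Nc1ccc(Oc2ncnc3[nH]ccc23)c(F)c1` gives 11700 nM in this assay, and compound 3 `Cc1cc(=O)n(-c2cccc(C(F)(F)F)c2)nc1C(=O)Nc1ccc(Oc2ncnc3[nH]ccc23)c(F)c1` gives 11800 nM. The steps of a 2.1-fold lower number from compound 1 to compound 2 (0.32 log units; beyond the scatter) and a 2.1-fold lower number from compound 1 to compound 3 (0.32 log units; beyond the scatter) are modest, while a 1.0-fold higher number from compound 2 to compound 3 (0.00 log units; within the scatter) shows that compound 2 and compound 3 cannot be told apart. Compound 2 therefore stands at the low end of the three numbers, separated from compound 1 but not from compound 3.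

Compound 4 `Cc1cc(=O)n(-c2ccccc2OC(F)(F)F)nc1C(=O)Nc1ccc(Oc2ncnc3c2ccn3C)c(F)c1` is compound 2 with methyl in place of hydrogen on an aromatic nitrogen. Among the compounds with values here, none of the measured steps touches this place; all three concern the aryl group on the other nitrogen, so no step bears directly on the change. Within the data shown here, with no relevant precedent, the expectation for compound 4 in this assay is a step of a 1.3-fold higher number from compound 2 to compound 4 (0.11 log units; within the scatter), that is none beyond the scatter, with a wide range. Compound 4 is estimated at 15000 nM, between 5000 nM and 60000 nM.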

Compound 4, half-maximal inhibitory concentration: > 60000 nM
Compound 4 gave a limit, no number; the forecaster's own chance of this, stated with the estimate: 10%; middle value at least 4.0-fold (0.60 log units) away from the limit.
By their numbers in this assay, from the lowest: compounds 2 and 3 (each within the scatter of the next); then compound 1. At a limit, above all of these: compound 4.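

Compound 4 shows that this place is not neutral in the series: methyl in place of hydrogen on an aromatic nitrogen of the five-membered aromatic ring gives an at least 5.1-fold higher number from compound 2 to compound 4 (0.70 log units; beyond the scatter). The earlier steps shown here all concerned the aryl group, and the largest of them was a 2.1-fold lower number from compound 1 to compound 2 (0.32 log units; beyond the scatter), so they gave no sign of how this nitrogen would respond. Compound 4 has a limit rather than a number in this assay, so the full size of its step remains unknown: the limit of > 60000 nM in this assay, at which 1 of the 4 values shown sits.

As far as these compounds go, whether an ethyl group, a longer chain or a chain ending in an amine on this nitrogen would give a measurable number remains open. Also open, from the compounds shown here alone, is whether methyl has the same effect alongside the 3-(trifluoromethyl)phenyl group of compound 3.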